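The source may report more compounds than this note shows. Statements on the series, on what has been measured and on what is new or still open speak of the compounds shown alone.

Measured so far in a functional assay on the whole organism with Mus musculus as the target; on this read-out higher numbers stand for an effect only at larger amounts of compound and lower numbers for an effect already at smaller amounts:
- Compound 1 `CN(C)C(=O)Cn1c(-c2cccc(Cl)c2)nc2cccnc21`: > 56.2 mg/kg; < 100 mg/kg (2 entries)
- Compound 2 `CN(C)C(=O)Cn1c(-c2ccc(F)cc2)nc2cccnc21`: 40.5 mg/kg
- Compound 3 `Cc1ccc(-c2nc3cccnc3n2CC(=O)N(C)C)cc1`: 4.7 mg/kg

The entry for compound 1 is a limit of the assay and not a number. Of the two single numbers, the lower belongs to compound 3, at 4.7 mg/kg, so on this assay it shows an effect at the smaller dose.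

The next compound, compound 4 `CN(C)C(=O)Cn1c(-c2ccc(Br)o2)nc2cccnc21`, has not yet been measured. It carries 5-bromofuran-2-yl in place of 4-methylphenyl on an aromatic carbon, so the whole ring changes: 5-bromofuran-2-yl in place of 4-methylphenyl on an aromatic carbon.

For the measured compounds named here, only one measured step bears on this, and only indirectly. It is an 8.6-fold lower number from compound 2 to compound 3 (0.94 log units; beyond the scatter), where methyl replaces fluoro on an aromatic carbon. Going by the values given here, that step shows that a small change in this part of the molecule can move the dose considerably, yet no measured step swaps the ring itself. Among the compounds with values here, compound 3 is also the only compound here with a number this low, so a higher number is more likely than a lower one.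

The expected change is a 4.3-fold higher number from compound 3 to compound 4 (0.63 log units; beyond the scatter), with wide uncertainty. Compound 4 is estimated at 20 mg/kg, with an expected range of 6 mg/kg to 70 mg/kg.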

Compound 4, dose for half-maximal effect: 100 mg/kg
Beside the measured number, compound 4's estimate is 5.0-fold (0.70 log units) below it; measured number above the stated range.
By their numbers in this assay, from the lowest: compound 3; then compound 2; then compound 4.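

The earlier compounds shown here showed only what happens when a small substituent on the phenyl ring changes, whereas this result shows what happens when the ring itself is replaced. In this assay, exchanging 4-methylphenyl for 5-bromofuran-2-yl gives a 21-fold higher number from compound 3 to compound 4 (1.33 log units; beyond the scatter), so the effect now needs a much larger dose, and the low number of the methyl compound does not survive this ring change. The exchange also loses ground against the fluorinated phenyl compound, with a 2.5-fold higher number from compound 2 to compound 4 (0.39 log units; beyond the scatter), so among the compounds with a single number, none with a phenyl ring at this position needs as large a dose as the bromofuran; no measurement shown gives a reason for this.

On these data alone, the ring and its substituent change together here, so it stays open whether the furan ring or the bromine accounts for the loss, and a furan carrying methyl in place of bromine would separate the two. As far as these compounds go, it also stays open whether the gain seen with methyl extends to other groups on the phenyl ring, such as methoxy or an amine.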